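Benzyl ether variation on a shared aryloxyethylamine core

The source may report more compounds than this note shows. Statements on the series, on what has been measured and on what is new or still open speak of the compounds shown alone.

Values so far in a functional assay on PC-3 cells (Homo sapiens) for cytotoxicity, read by sulforhodamine B assay; a lower number here means a stronger inhibitor of growth, a higher number a weaker inhibitor of growth:
compound 1 `COc1cccc(OC)c1OCCNCCOc1ccccc1OCc1ccccc1` gives 26900 nM
compound 2 `COc1cccc(OC)c1OCCNCCOc1ccccc1OCc1ccc(C)cc1` gives 7800 nM

Going by the values given here, compound 2 stands at the lower of the two numbers in this assay; the only other number lies higher, by a 3.4-fold lower number from compound 1 to compound 2 (0.54 log units; beyond the scatter), a difference beyond the scatter. Compound 3 `COc1cccc(OC)c1OCCNCCOc1ccccc1OCc1ccccc1[N+](=O)[O-]` is not yet measured. It differs from compound 2 by 2-nitrophenyl in place of 4-methylphenyl on a saturated chain carbon bound to an oxygen on an aromatic ring. Among the compounds with values here, the single measured step bears on this change only through the methyl, which compound 3 gives up: that step was a 3.4-fold lower number from compound 1 to compound 2 (0.54 log units; beyond the scatter), so loss of the methyl alone would be expected to move the number back toward compound 1. Within the data shown here, for the nitro group no measured step exists, so its contribution is unknown. On balance the expected step is a 1.9-fold higher number from compound 2 to compound 3 (0.28 log units; within the scatter), upward. Compound 3 is therefore expected to give about 15000 nM in this assay, with a range of 5000 nM to 45000 nM.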

Compound 3, concentration for 50% growth inhibition: 13200 nM
Beside the measured number, compound 3's estimate is 1.1-fold (0.06 log units) above it; the range from low to high includes it.
By their numbers in this assay, from the lowest: compounds 2 and 3 (each within the scatter of the next); then compound 1.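

Placing a nitro group on the benzyl ring gives a 2.0-fold lower number from compound 1 to compound 3 (0.31 log units; beyond the scatter) in this assay, so the benzyl ring of compound 1 now has a second substituent with a step beyond the scatter, though a modest one. Exchanging 4-methylbenzyl for 2-nitrobenzyl gives a 1.7-fold higher number from compound 2 to compound 3 (0.23 log units; within the scatter), which leaves these two substituted benzyl ethers indistinguishable in this read-out although the group and its printed ring number both differ. Nothing available here explains why either group shifts the number from that of compound 1.

The compounds shown do not separate the identity of the group from its place on the ring; 2-methylbenzyl and 4-nitrobenzyl ethers would bear on that. As far as these compounds go, how an amine or a carboxylic acid on the same ring would read in this assay also remains open.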